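Replacing a hydroxypyrrolidine with an amino acid on the benzyl arm

A few compounds are considered here, and "the series" means these few. Any claim that something is new, unique, unknown or untested is made for them only; others in the source may bear on it.

Measured compounds:
Compound 1 `COc1ccc(/C=C\c2cc(OC)c(OC)c(OC)c2)cc1OCc1ccc(CN2CC[C@@H](O)C2)cc1`: in a functional assay on HeLa cells (Homo sapiens) for antiproliferative activity, read by CCK-8 assay, with a stated time of 48 h (on this read-out higher numbers stand for weaker inhibition and lower numbers for stronger inhibition), compound 1 gives > 10000 nM, which is a limit of the assay and not a number.
Compound 2 `COc1ccc(/C=C\c2cc(OC)c(OC)c(OC)c2)cc1OCc1ccc(CN2CC[C@H](O)C2)cc1`: compound 2 gives 10500 nM.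
Compound 3 `COc1ccc(/C=C\c2cc(OC)c(OC)c(OC)c2)cc1OCc1ccc(CN2CCCCC2C(=O)NCCNC(=O)OC(C)(C)C)cc1`: compound 3 gives 2000 nM.

Compound 2 holds the highest of the two numbers recorded; compound 3 sits at a lower number, and that gap lies beyond the scatter. The step that the limit leaves unreadable from compound 1 to compound 2 cannot be sized because of the limit of > 10000 nM in this assay, at which 1 of the 3 values shown sits; it rests on the fact that compounds 1 and 2 differ only in the configuration as drawn and therefore concerns only the drawn configuration, not the group itself.

Compound 4 `COc1ccc(/C=C\c2cc(OC)c(OC)c(OC)c2)cc1OCc1ccc(CNC(C)(C)C(=O)O)cc1` carries the change ((1-carboxy-1-methylethyl)amino in place of 3-hydroxypyrrolidin-1-yl on a saturated chain carbon bound to an aromatic carbon). Among the measured compounds shown here, no measured step here alters the group on the saturated chain carbon bound to an aromatic carbon, so no step bears directly on this change. For the measured compounds named here, the only readable comparison, between compound 2 and compound 3, shows that a different substituent at this position can give a lower number, but the two groups are unrelated to the one entering. The expectation is therefore a step of a 1.3-fold lower number from compound 2 to compound 4 (0.12 log units; within the scatter) that stays near the scatter, with the direction uncertain. Compound 4 is estimated at 8000 nM, within a range from 2500 nM to 25000 nM.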

Compound 4, half-maximal inhibitory concentration: > 10000 nM
Compound 4: only a limit was reported (the forecaster's own chance of this, stated with the estimate: 35%); middle value at least 1.2-fold (0.09 log units) away from the limit.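

In this assay compound 4 gives > 10000 nM, which is a limit of the assay and not a number, so the steps from compound 1 and from compound 2 to compound 4 cannot be read. The compounds shown leave open whether (1-carboxy-1-methylethyl)amino in place of 3-hydroxypyrrolidin-1-yl shifts the number at all, and by how much.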